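Longer Chains in Two Cores of a Liver Enzyme Inhibitor

The compounds below may be only part of what the source reports. "The series", "measured", "known", "first", "only" and "open" are said of these compounds alone.

Measured compounds:
compound 1, `CCCCCCCCCCCCCCN(C)S(=O)(=O)NC(=O)Nc1c(C(C)C)cccc1C(C)C`, giving 330 nM in an assay on liver for inhibition of sterol O-acyltransferase 1 (Rattus norvegicus), using microsomes; a higher number here means a weaker inhibitor, a lower number a stronger inhibitor
compound 2, `CCCCCCCCCCCCCCCCCCN(C)S(=O)(=O)NC(=O)Nc1c(C(C)C)cccc1C(C)C`, giving 1900 nM in this assay
compound 3, `CCCCCCCCCCCCOS(=O)(=O)NC(=O)Oc1c(C(C)C)cccc1C(C)C`, giving 13000 nM in this assay

Compound 1 and compound 2 share one core and differ by butyl in place of hydrogen on a saturated chain carbon, ten or more bonds along the chain from a sulfonamide nitrogen. That change gave a 5.8-fold higher number from compound 1 to compound 2 (0.76 log units; beyond the scatter), so the longer chain made the inhibitor weaker. Compound 3 has a different core; the difference between the two cores is not broken down here. Compound 3 shows the highest number of the three in this assay.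

Compound 4, `CCCCCCCCCCCCCCCCOS(=O)(=O)NC(=O)Oc1c(C(C)C)cccc1C(C)C`, has not been measured. It differs from compound 3 by butyl in place of hydrogen on a saturated chain carbon, ten or more bonds along the chain from an oxygen on an unsaturated carbon. The place is not the same word for word as in the first pair: there the chain carbon is counted along the chain from a sulfonamide nitrogen, here along the chain from an oxygen on an unsaturated carbon, so this is the same kind of change, not the same change.

From compound 3 to compound 4 the expected step is a 4.6-fold higher number from compound 3 to compound 4 (0.66 log units; beyond the scatter), resting on compound 1 and compound 2 because a 5.8-fold higher number from compound 1 to compound 2 (0.76 log units; beyond the scatter) pointed to a weaker inhibitor. Compound 4 is therefore estimated at 60000 nM, between 15000 nM and 250000 nM.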

Compound 4, half-maximal inhibitory concentration: 10300 nM
Compound 4: the middle estimate sits 5.8-fold (0.77 log units) above what was measured; measured number outside the range, below it.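

In this assay, butyl in place of hydrogen on a saturated chain carbon gave a 1.3-fold lower number from compound 3 to compound 4 (0.10 log units; within the scatter), so this pair cannot be told apart in this assay. The same kind of change therefore did not behave alike on the two cores, and the gap between the two steps is real: the same change on two cores in this assay, a 5.8-fold higher number (0.76 log units; beyond the scatter) from compound 1 to compound 2 and a 1.3-fold lower number (0.10 log units; within the scatter) from compound 3 to compound 4, 7.3-fold (0.86 log units) apart, beyond the scatter of two such steps This shows that, in these two pairs, a step seen on the core of compound 1 could not be carried over to the core of compound 3, but with one pair per core it does not show which part of the cores matters or why the steps part ways.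

For the compounds shown here, each core appears here with only one pair of chains, so it stays open how the numbers would run with a shorter chain such as octyl, or with a chain ending in an amine or a carboxylic acid. Also open, from the compounds shown here alone, is whether a core carrying only part of the difference between the two cores would follow compound 1 and compound 2 or compound 3 and compound 4.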